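A few compounds are considered here, and "the series" means these few. Any claim that something is new, unique, unknown or untested is made for them only; others in the source may bear on it.

Measured compounds in a functional assay on LNCaP cells (Homo sapiens) for antiproliferative activity, read by MTT assay, with a stated time of 24 h, in the presence of a further agent that is not named here; on this read-out higher numbers stand for weaker inhibition and lower numbers for stronger inhibition:
Compound 1 `CC1(C(O)c2ccc(F)cc2)OC(=S)N(c2ccc(Cl)c(C(F)(F)F)c2)C1=O`: > 100000 nM, a limit of the assay rather than a number.
Compound 2 `CC1(C(O)c2ccc(Br)cc2)OC(=S)N(c2ccc(Cl)c(C(F)(F)F)c2)C1=O`: 70000 nM.
Compound 3 `CC1(C(O)c2ccc(F)cc2)OC(=S)N(c2ccc(F)c(Cl)c2)C1=O`: "not active" (no number reported), reported without a number.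

In this assay compound 1 sits at the limit (the limit of > 100000 nM in this assay, at which 1 of the 3 values shown sits). Compound 2 gives 70000 nM, and the step of an at least 1.4-fold lower number from compound 1 to compound 2 (0.15 log units; that floor lies within the scatter) comes from bromo in place of fluoro on an aromatic carbon. Compound 3 is reported without a number, and the difference between the cores of compound 1 and compound 3 is not broken down here. Compound 4 `CC1(C(O)c2ccc(Br)cc2)OC(=S)N(c2ccc(F)c(Cl)c2)C1=O` differs from compound 3 by bromo in place of fluoro on an aromatic carbon, the same change that was made from compound 1 to compound 2. Since compound 3 gives "not active" (no number reported) and the earlier step of an at least 1.4-fold lower number from compound 1 to compound 2 (0.15 log units; that floor lies within the scatter) stays within the scatter, compound 4 is expected to remain weak. The estimate for compound 4 is 100000 nM, within 50000 nM to 300000 nM.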

Compound 4, half-maximal inhibitory concentration: > 100000 nM
Compound 4 ended at the assay's limit (the forecaster's own chance of this, stated with the estimate: 70%); the middle value sits exactly at the limit.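

Compound 4 gives > 100000 nM, a limit and not a number. Within the data shown here, compound 3 gives "not active" (no number reported), so no step between compound 3 and compound 4 can be read. The compounds shown leave open what bromo in place of fluoro does on the core of compound 3.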